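Benzyl substituent swaps at the piperidine nitrogen

The source may report more compounds than this note shows. Statements on the series, on what has been measured and on what is new or still open speak of the compounds shown alone.

Compound 1 `Cc1ccccc1CN1CCC(c2noc(COc3ccc(/C=C/C(=O)NO)cc3)n2)CC1` is the reference point. In an assay on isolated protein for inhibition of protein deacetylase HDAC6 (Homo sapiens), read by fluorescence, with a stated time of 1 h, tested at 100 nM (a higher number here means more inhibition at the concentration tested (going by the name of the read-out), a lower number less inhibition), compound 1 gives 68%, level with compound 2 `O=C(/C=C/c1ccc(OCc2nc(C3CCN(Cc4ccccc4F)CC3)no2)cc1)NO` at 68% within the scatter; compound 3 `O=C(/C=C/c1ccc(OCc2nc(C3CCN(Cc4ccc(F)c(F)c4)CC3)no2)cc1)NO` gives 60%, also within the scatter of both. Compound 4 `O=C(/C=C/c1ccc(OCc2nc(C3CCN(Cc4ccc(Br)cc4)CC3)no2)cc1)NO` is unmeasured and differs from compound 1 by 4-bromophenyl in place of 2-methylphenyl on a saturated chain carbon bound to an amine nitrogen in a ring. Among the compounds with values here, three measured steps bear on this site: no change at the digits printed from compound 1 to compound 2 (within the scatter), a number 8 percentage points lower from compound 1 to compound 3 (within the scatter) and a number 8 percentage points lower from compound 2 to compound 3 (within the scatter). No exchange of the group on this carbon has yet moved this assay beyond the scatter. The expected step, a number 4 percentage points lower from compound 1 to compound 4 (within the scatter), is of the same kind, small and without clear direction. Compound 4 is estimated at 64%, with a range of 50% to 76%.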

Compound 4, a percentage reported as inhibition, at one concentration (the size of the read-out at that concentration, not a potency): 58%
Compound 4: the middle estimate sits 6 percentage points above what was measured; the range from low to high includes it.
By their numbers in this assay, from the lowest: compounds 4, 3, 1 and 2 (each within the scatter of the next).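

The 4-bromophenyl group also stays within the scatter in this assay: a number 10 percentage points lower from compound 1 to compound 4 (within the scatter), a number 10 percentage points lower from compound 2 to compound 4 (within the scatter) and a number 2 percentage points lower from compound 3 to compound 4 (within the scatter). Bromine therefore joins methyl and fluoro among the substituents on this benzyl group, and across these four compounds no exchange at this carbon separates from any other. No measurement on hand accounts for these values.

Open, on these data alone, is whether a carboxylic acid or an amine on the phenyl ring, or a longer chain in place of the benzyl group, would move this assay beyond the scatter.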